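The source may report more compounds than this note shows. Statements on the series, on what has been measured and on what is new or still open speak of the compounds shown alone.

Compound 3 `COc1ccc(C(=O)c2cc(OC)c(OC)c(OC)c2)cc1NC(=O)/C=C/c1cccc(OC(F)(F)F)c1` gives 5200 nM in a functional assay on HT-29 cells (Homo sapiens) for cytotoxicity, read by MTT assay, with a stated time of 72 h (a higher number here means a weaker inhibitor, a lower number a stronger inhibitor), the highest of the three numbers shown, although its gap to compound 2 is within the scatter: compound 2 `COc1ccc(/C=C/C(=O)Nc2cc(C(=O)c3cc(OC)c(OC)c(OC)c3)ccc2OC)cc1` gives 5010 nM and compound 1 `COc1ccc(C(=O)c2cc(OC)c(OC)c(OC)c2)cc1NC(=O)/C=C/c1ccc(OC)c(OC)c1` gives 2500 nM. Compound 4 `COc1ccc(C(=O)c2cc(OC)c(OC)c(OC)c2)cc1NC(=O)/C=C/c1ccc([N+](=O)[O-])cc1` differs from compound 3 by 4-nitrophenyl in place of 3-(trifluoromethoxy)phenyl on a double-bonded chain carbon bound to a double-bonded chain carbon. Two measured steps exchange the same aryl group at that place: a 2.1-fold higher number from compound 1 to compound 3 (0.32 log units; beyond the scatter) and a 1.0-fold higher number from compound 2 to compound 3 (0.02 log units; within the scatter). Both are small, so another exchange there is expected to move the number in this assay little, if anything towards a slightly lower value. Compound 4 is therefore estimated at 4000 nM, with a range from 1800 nM to 9000 nM. The expected step is a 1.3-fold lower number from compound 3 to compound 4 (0.11 log units; within the scatter), which would stay within the scatter.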

Compound 4, half-maximal inhibitory concentration: 5100 nM
Beside the measured number, compound 4's estimate is 1.3-fold (0.11 log units) below it; low and high end bracket the measured number.
By their numbers in this assay, from the lowest: compounds 1, 2, 4 and 3 (each within the scatter of the next, the first and the last beyond it).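

In this assay, 4-nitrophenyl at this place on a double-bonded chain carbon adds a third aryl group that sits level with two earlier ones: 3-(trifluoromethoxy)phenyl (a 1.0-fold lower number from compound 3 to compound 4 (0.01 log units; within the scatter)) and, with nitro in place of methoxy, 4-methoxyphenyl (a 1.0-fold higher number from compound 2 to compound 4 (0.01 log units; within the scatter)). Only against 3,4-dimethoxyphenyl does a modest gap appear (a 2.0-fold higher number from compound 1 to compound 4 (0.31 log units; beyond the scatter)), although compound 2 stays within the scatter of compound 1. Nothing measured here explains this result. On these data alone, whether an amine or a carboxylic acid on this phenyl ring would move the number remains open.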